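The source may hold more compounds than are shown below. What is called first, only, known or untested is meant among the compounds shown, and "the series" means these compounds.

In a functional assay on MDA-MB-231 cells (Homo sapiens) for cytotoxicity, read by MTT assay, with a stated time of 24 h (on this read-out higher numbers stand for weaker inhibition and lower numbers for stronger inhibition), the measured compounds are:

compound 1 `Cc1cc(O)c(C(=O)/C=C/c2ccc(Cl)cc2)c(-c2ccccc2)c1C(=O)/C=C/c1ccc(Cl)cc1`, which gives 7900 nM;
compound 2 `Cc1cc(O)c(C(=O)/C=C/c2ccc(Cl)cc2)c(-c2ccc(OCc3ccccc3)cc2)c1C(=O)/C=C/c1ccc(Cl)cc1`, which gives 30000 nM;
compound 3 `COc1ccc(/C=C/C(=O)c2c(C)cc(O)c(C(=O)/C=C/c3ccc(OC)c(OC)c3)c2-c2ccccc2)cc1OC`, which is reported as "not active" (no number reported).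

Compound 1 and compound 2 share one core and differ only by benzyloxy in place of hydrogen on an aromatic carbon. That single change produced a 3.8-fold higher number from compound 1 to compound 2 (0.58 log units; beyond the scatter), so the larger group moved the read-out toward weaker inhibition.

Compound 4 `COc1ccc(/C=C/C(=O)c2c(C)cc(O)c(C(=O)/C=C/c3ccc(OC)c(OC)c3)c2-c2ccc(OCc3ccccc3)cc2)cc1OC` is the still unmeasured partner of compound 3. For the measured compounds named here, the change from compound 3 to compound 4 is benzyloxy in place of hydrogen on an aromatic carbon, and it is the same change, at the same kind of place, as the one from compound 1 to compound 2. How the core of compound 3 differs from the core of compound 1 is not broken down here.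

Going by the values given here, because compound 3 is reported as "not active" (no number reported), no numerical step can be computed for the pair, and the one observed step, a 3.8-fold higher number from compound 1 to compound 2 (0.58 log units; beyond the scatter), points toward a higher number, not a lower one. Compound 4 is therefore expected to be weak in this assay, with an estimated value near 60000 nM. The expected range for compound 4 runs from 15000 nM to 250000 nM. It is also quite likely that compound 4 again yields only a limit rather than a number.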

Compound 4, half-maximal inhibitory concentration: 22000 nM
Compound 4: the middle estimate sits 2.7-fold (0.44 log units) above what was measured, within the range that was stated.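

In this assay compound 4 gives 22000 nM, while compound 3 is reported only as "not active", so no step can be read between compound 3 and compound 4. The compounds shown leave open whether benzyloxy shifts the read-out on this core as it does on the core of compound 1. No evidence bearing on this result is available.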